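A Group Swap on a Core at the Assay Limit

The source may report more compounds than this note shows. Statements on the series, on what has been measured and on what is new or still open speak of the compounds shown alone.

- Compound 1 `CC(C)(C)c1ccc(C(=O)NNc2c(Br)cccc2Br)cc1`: > 100000 nM (a limit)
- Compound 2 `CN(C)c1ccc(C(=O)NNc2c(Br)cccc2Br)cc1`: > 100000 nM (a limit)

In a toxicity assay on MDCK cells (Canis lupus familiaris) for cytotoxicity, read by CCK-8 assay, with a stated time of 48 h (a lower number here means that less compound is tolerated, a higher number that more compound is tolerated), compound 2 gives > 100000 nM, a limit of the assay and not a number. Compound 3 `O=C(NNc1c(Br)cccc1Br)c1ccc(B(O)O)cc1` changes one group: a group of 3 heavy atoms (1 boron, 2 oxygen; no ring) in place of a group of 3 heavy atoms (2 carbon, 1 nitrogen; no ring), on an aromatic carbon. Among the measured compounds shown here, the only measured step bearing on this, a step that the two limits leave unreadable from compound 1 to compound 2, changed the group at that same place, and its size cannot be read. All the evidence is the limit of > 100000 nM in this assay, at which 2 of the 2 values shown sit. No step beyond the scatter is therefore expected in this assay, though the limits leave room for surprise. Expected here is a number no higher from compound 2 to compound 3 (the limit leaves the size open). For compound 3 the estimated value is 100000 nM, with an expected range from 40000 nM to 250000 nM.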

Compound 3, half-maximal cytotoxic concentration: > 100000 nM
Compound 3: no number, only a limit (the forecaster's own chance of this, stated with the estimate: 70%); the middle value sits exactly at the limit.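

Among the compounds shown here, no step among compound 1, compound 2 and compound 3 can be read in this assay, as each gives only a limit and not a number. Left open is whether these groups differ in how much compound the cells tolerate: the limit of > 100000 nM in this assay, at which 3 of the 3 values shown sit.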